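Adding a trifluoromethyl group to a compound without a number

The compounds below may be only part of what the source reports. "The series", "measured", "known", "first", "only" and "open" are said of these compounds alone.

For the measured compounds named here, in a functional assay on NALM-6 cells (Homo sapiens) for cytotoxicity, read by luminescence and CellTiter-Glo, with a stated time of 3 days (a lower number here means a stronger inhibitor, a higher number a weaker inhibitor), compound 2 `O=C(Nc1ccc([N+](=O)[O-])cc1)c1cc(F)ccc1O` gives 2080 nM as the only number so far. Compound 1 `N#Cc1cccc(NC(=O)c2cc(F)ccc2O)c1` reads "not determined" (no result reported) and offers no comparison. Compound 3 `O=C(Nc1ccccc1)c1cc(F)ccc1O` also reads "not determined" (no result reported) and so has no place on the scale. One change leads from compound 3 to compound 4 `O=C(Nc1cccc(C(F)(F)F)c1)c1cc(F)ccc1O` with trifluoromethyl in place of hydrogen on an aromatic carbon as its count: trifluoromethyl in place of hydrogen on an aromatic carbon. Going by the values given here, no measured pair shows what such a change does, so a modest step towards stronger inhibition in this assay is expected only tentatively. Among the compounds with values here, the sole anchor is compound 2 at 2080 nM on a related structure. Compound 4 is estimated at 2000 nM within an expected range of 500 nM to 8000 nM for now.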

Compound 4, half-maximal inhibitory concentration: 1800 nM
For compound 4 the middle estimate is 1.1-fold (0.05 log units) above the measured one; low and high end bracket the measured number.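

Compound 3 has no number to set against compound 4, so no step can be read between them. As far as these compounds go, what trifluoromethyl in place of hydrogen does to inhibition stays open, and no supporting measurement bears on this result.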